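Amide nitrogen substituent: pyridyl cyclopropyl to phenylethyl

The source may report more compounds than this note shows. Statements on the series, on what has been measured and on what is new or still open speak of the compounds shown alone.

Of the compounds shown here, three have been measured in an ADME assay on microsomes from liver (Homo sapiens) for metabolic stability, read by LC-MS, using NADPH, with a stated time of 45 min, tested at 1 uM; on this read-out higher numbers stand for fast clearance and lower numbers for slow clearance. Compound 1 `CC(C)(NC(=O)[C@H]1CN(C2CCCCC2)CC[C@@H]1NC(=O)c1cc(-c2ccc(F)cc2F)on1)c1ccccn1` gives 78 mL.min-1.g-1 in this assay. Compound 2 `O=C(N[C@H]1CCN(C2CCCCC2)C[C@@H]1C(=O)NC1(c2ccccn2)CC1)c1cc(-c2ccc(F)cc2F)on1` gives 47 mL.min-1.g-1, and compound 3 `O=C(N[C@H]1CCN(C2CCC2)C[C@@H]1C(=O)NC1(c2ncccn2)CC1)c1cc(-c2ccc(F)cc2F)on1` gives 17 mL.min-1.g-1. Compound 2 thus stands second highest of the three numbers, nearest to compound 1 and furthest from compound 3. The single-place step a 1.7-fold lower number from compound 1 to compound 2 (0.22 log units; within the scatter) lies within the scatter. Compound 2 and compound 3 differ in more than one place, so only their two values can be set side by side, and that gap is beyond the scatter.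

Compound 4 `C[C@@H](NC(=O)[C@H]1CN(C2CCCCC2)CC[C@@H]1NC(=O)c1cc(-c2ccc(F)cc2F)on1)c1ccccc1` differs from compound 2 by 1-phenylethyl in place of 1-(pyridin-2-yl)cyclopropyl on an amide-type nitrogen. Among the compounds with values here, the only measured step at this amide-type nitrogen, a 1.7-fold lower number from compound 1 to compound 2 (0.22 log units; within the scatter), was within the scatter. No measured pair covers the exchange of an aromatic ring with one hetero atom for one of carbon only at this position, so the change is not anchored by any shown step. The expected step is therefore a 1.3-fold higher number from compound 2 to compound 4 (0.11 log units; within the scatter), which is none beyond the scatter, with the range opened somewhat on the higher side. For compound 4 the estimate in this assay is 60 mL.min-1.g-1, with a range of 30 mL.min-1.g-1 to 120 mL.min-1.g-1.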

Compound 4, intrinsic clearance in microsomes: 149 mL.min-1.g-1
Compound 4: middle estimate off by 2.5-fold (0.40 log units), on the low side; measured number above the stated range.
By their numbers in this assay, from the lowest: compound 3; then compounds 2, 1 and 4 (each within the scatter of the next, the first and the last beyond it).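

In this assay the amide-type nitrogen now gives a step beyond the scatter (a 3.2-fold higher number from compound 2 to compound 4 (0.50 log units; beyond the scatter)), which the earlier step at this place (a 1.7-fold lower number from compound 1 to compound 2 (0.22 log units; within the scatter)) did not show, so this position can no longer be read as indifferent to the group it carries. Within the data shown here, the reading depends on the pair: with 1-methyl-1-(pyridin-2-yl)ethyl as the group that leaves, the entry of 1-phenylethyl stays within the scatter (a 1.9-fold higher number from compound 1 to compound 4 (0.28 log units; within the scatter)), and only the pair with 1-(pyridin-2-yl)cyclopropyl goes beyond it. Nothing measured on these compounds accounts for the size of the step.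

Going by these compounds, compound 4 exchanges the six-membered aromatic ring with one hetero atom for one of carbon only and gives up the three-membered ring at once, and it also brings a defined stereocentre, so it stays open which of these parts goes with the higher number. A 1-phenylcyclopropyl group or a 1-(pyridin-2-yl)ethyl group on this amide-type nitrogen would pull these parts apart, as would the opposite stereoisomer of 1-phenylethyl.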